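Moving the Bromine on a Second Dimethoxy Core

The source may report more compounds than this note shows. Statements on the series, on what has been measured and on what is new or still open speak of the compounds shown alone.

Compound 1 `COc1cccc(/C=C2\CCC/C(=C\c3ccccc3Br)C2=O)c1OC` and compound 2 `COc1cccc(/C=C2\CCC/C(=C\c3cccc(Br)c3)C2=O)c1OC` share one core, while compound 3 `COc1ccc(/C=C2\CCC/C(=C\c3ccccc3Br)C2=O)cc1OC` and compound 4 `COc1ccc(/C=C2\CCC/C(=C\c3cccc(Br)c3)C2=O)cc1OC` share another; the difference between the two cores is not broken down here. In a functional assay on HT-1080 cells (Homo sapiens) for cytotoxicity, read by MTT assay, with a stated time of 72 h (on this read-out lower numbers stand for stronger inhibition and higher numbers for weaker inhibition), compound 1 gives 10800 nM and compound 2 gives 12200 nM. The change between them, (3-bromophenyl in place of 2-bromophenyl on a double-bonded chain carbon bound to a double-bonded ring carbon), made a step of a 1.1-fold higher number from compound 1 to compound 2 (0.05 log units; within the scatter). In this assay compound 3 gives 8400 nM. Compound 4 arises from compound 3 by the same change, (3-bromophenyl in place of 2-bromophenyl on a double-bonded chain carbon bound to a double-bonded ring carbon), at the same place, but has not yet been measured. The step to compound 4 is estimated at a 1.1-fold higher number from compound 3 to compound 4 (0.05 log units; within the scatter), resting on the earlier step of a 1.1-fold higher number from compound 1 to compound 2 (0.05 log units; within the scatter), which stayed within the scatter. Compound 4 is therefore expected to give about 9500 nM, with a likely range from 5000 nM to 18000 nM.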

Compound 4, half-maximal inhibitory concentration: 5200 nM
Compound 4: middle estimate off by 1.8-fold (0.26 log units), on the high side; low and high end bracket the measured number.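

On the second core, 3-bromophenyl in place of 2-bromophenyl gives a 1.6-fold lower number from compound 3 to compound 4 (0.21 log units; within the scatter) in this assay. Set beside the same change on the first core, this step shows no real difference between the two cores, and each step stays within the scatter: the same change on two cores in this assay, a 1.1-fold higher number (0.05 log units; within the scatter) from compound 1 to compound 2 and a 1.6-fold lower number (0.21 log units; within the scatter) from compound 3 to compound 4, 1.8-fold (0.26 log units) apart, within the scatter of two such steps This supports no claim that the effect depends on the core, but steps this small, seen on only two cores, do not show that the change has any real effect or that it would carry over in the same way to other cores.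

Going by these compounds, it remains open how the number would move if a chlorine, a methoxy group or an amine replaced the bromine. How the two cores themselves compare also remains unresolved.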